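This account rests on a few compounds, and the source may have more. Where it says the series, first, only, none or still open, it means among the compounds named here.

Compound 1: `CCCCC(=O)Oc1cc(/C=C/C(=O)c2ccc(OC)c3c2OC(C)(C)C=C3)ccc1OC` — 220 nM
Compound 2: `COc1ccc(/C=C/C(=O)c2ccc(OC)c3c2OC(C)(C)C=C3)cc1OC(=O)C(C)C` — 310 nM

In a functional assay on A-375 cells (Homo sapiens) for cytotoxicity, read by MTT assay (a higher number here means a weaker inhibitor, a lower number a stronger inhibitor), compound 1 gives 220 nM, the lowest of the two numbers shown, though a 1.4-fold higher number from compound 1 to compound 2 (0.15 log units; within the scatter) lies within the scatter, so compound 1 and compound 2 are not distinguished by this assay. Compound 3 `COc1ccc(/C=C/C(=O)c2ccc(OC)c3c2OC(C)(C)C=C3)cc1OC(=O)c1ccc(Br)cc1` differs from compound 1 by 4-bromophenyl in place of butyl on a carbonyl carbon. Among the compounds with values here, only one measured step bears on this position on the carbonyl carbon: a 1.4-fold higher number from compound 1 to compound 2 (0.15 log units; within the scatter), which exchanges one chain for another and stays within the scatter. Within the data shown here, no measured step tests a 4-bromophenyl, or any aromatic ring, at this place, so the expectation for compound 3 rests on a single small step. Compound 3 is therefore expected to give a number close to that of compound 1, with a 1.6-fold higher number from compound 1 to compound 3 (0.20 log units; within the scatter) and no clear direction. The estimate for compound 3 in this assay is 350 nM, with a range from 120 nM to 1100 nM.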

Compound 3, half-maximal inhibitory concentration: 420 nM
Estimate against measurement, compound 3: 1.2-fold (0.08 log units) below; the range from low to high includes it.
By their numbers in this assay, from the lowest: compounds 1, 2 and 3 (each within the scatter of the next).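

This position on a carbonyl carbon accepts an aromatic ring as well as a chain without a change that this assay can resolve: 4-bromophenyl in place of butyl gives a 1.9-fold higher number from compound 1 to compound 3 (0.28 log units; within the scatter) and 4-bromophenyl in place of isopropyl gives a 1.4-fold higher number from compound 2 to compound 3 (0.13 log units; within the scatter) in the second comparison. Both steps lie within the scatter, so compound 1, compound 2 and compound 3 are not distinguished, even though the group entering holds more heavy atoms, a six-membered aromatic ring and a bromine. Nothing measured here explains this result.

The compounds shown leave open whether the ring or the bromine contributes anything, as a plain phenyl at this place would test. They also leave open how this position would respond to an amine, a carboxylic acid or a chain longer than butyl.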